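The source may report more compounds than this note shows. Statements on the series, on what has been measured and on what is new or still open speak of the compounds shown alone.

Measured so far:
- compound 1 `CC1=C2[C@H](/C=C(\C)C(=O)NCc3ccccc3)CC[C@@H](C)[C@H]2CC1`: 9000 nM
- compound 2 `CC1=C2[C@H](/C=C(\C)C(=O)NCc3ccccc3F)CC[C@@H](C)[C@H]2CC1`: 8700 nM

In an ADME assay on cells (Keratinocyte, Homo sapiens) for inhibition, read by fluorescence, with stated times of 2 h and 72 h (on this read-out lower numbers stand for stronger inhibition and higher numbers for weaker inhibition), compound 2 gives 8700 nM and compound 1 gives 9000 nM. These two values lie within the scatter of each other, so they cannot be ranked.

The next analogue is compound 3 `CC1=C2[C@H](/C=C(\C)C(=O)NCc3cccc(F)c3)CC[C@@H](C)[C@H]2CC1`, which has 3-fluorophenyl in place of 2-fluorophenyl on a saturated chain carbon bound to an amide-type nitrogen.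

For the measured compounds named here, only one measured step bears on this change, and only indirectly. That step, a 1.0-fold lower number from compound 1 to compound 2 (0.01 log units; within the scatter), is fluoro in place of hydrogen on an aromatic carbon, and it lies within the scatter. Going by the values given here, no measured pair yet shows the effect of replacing 2-fluorophenyl with 3-fluorophenyl, so this expectation rests on thin evidence. Among the compounds with values here, with compound 2 at 8700 nM and no step beyond the scatter so far, none is expected in this assay here, and no direction is favoured.

The estimated step is a 1.0-fold higher number from compound 2 to compound 3 (0.00 log units; within the scatter), expected to stay within the scatter. For compound 3 the expected value is 8800 nM, with an estimated range of 5000 nM to 15000 nM.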

Compound 3, half-maximal inhibitory concentration: 9600 nM
Compound 3: middle estimate off by 1.1-fold (0.04 log units), on the low side; measured number inside the range.
By their numbers in this assay, from the lowest: compounds 2, 1 and 3 (each within the scatter of the next).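

Working notes: in this assay, 3-fluorophenyl in place of 2-fluorophenyl on a saturated chain carbon bound to an amide-type nitrogen gives a 1.1-fold higher number from compound 2 to compound 3 (0.04 log units; within the scatter), the first direct comparison of two fluorophenyl isomers at this place. Fluoro in place of hydrogen now has a second reading, a 1.1-fold higher number from compound 1 to compound 3 (0.03 log units; within the scatter), so both fluorinated compounds lie within the scatter of the unsubstituted compound 1, and compound 1, compound 2 and compound 3 cannot be ranked. No evidence beyond these numbers bears on the result.

Fluoro is the only substituent shown on this phenyl ring, so these compounds do not tell whether the place can produce a step beyond the scatter with a different group, such as methoxy, trifluoromethyl, an amine or a carboxylic acid. Also open, from the compounds shown here alone, is what a longer chain in place of the benzyl group, or any change to the shared core, would give in this assay.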